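A few compounds are considered here, and "the series" means these few. Any claim that something is new, unique, unknown or untested is made for them only; others in the source may bear on it.

Compound 1 `CC(C)CCc1c(OCCCCCCCC(=O)NO)ccc2ccc(=O)oc12` and compound 3 `CC(C)CCc1c(OCCCCC(=O)NO)ccc2ccc(=O)oc12` are built on one core, while compound 2 `CC(C)CCc1c(OCCCCCCCC(=O)NO)ccc(CCC(=O)NO)c1O` and compound 4 `CC(C)CCc1c(OCCCCC(=O)NO)ccc(CCC(=O)NO)c1O` are built on another; the difference between the two cores is not broken down here. In a functional assay on Hep 3B2 cells (Homo sapiens) for antiproliferative activity, read by sulforhodamine B assay, with a stated time of 48 h (on this read-out higher numbers stand for weaker inhibition of growth and lower numbers for stronger inhibition of growth), compound 1 gives 3580 nM, compound 3 gives 1310 nM, and compound 2 gives 1270 nM. The move from compound 1 to compound 3 is a single change, (hydroxycarbamoyl in place of 3-(hydroxycarbamoyl)propyl on a saturated chain carbon, four bonds along the chain from an oxygen on an aromatic ring), and it brings a 2.7-fold lower number from compound 1 to compound 3 (0.44 log units; beyond the scatter). Compound 4 carries the same change on the other core, (hydroxycarbamoyl in place of 3-(hydroxycarbamoyl)propyl on a saturated chain carbon, four bonds along the chain from an oxygen on an aromatic ring), and is not yet measured in this assay. For compound 4 the expected step is a 1.7-fold lower number from compound 2 to compound 4 (0.23 log units; within the scatter), set a little smaller than the earlier one because a 2.7-fold lower number from compound 1 to compound 3 (0.44 log units; beyond the scatter) was seen only once and on a different core. Compound 4 is therefore estimated at 750 nM, with a likely range from 350 nM to 1600 nM.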

Compound 4, concentration for 50% growth inhibition: 14100 nM
Beside the measured number, compound 4's estimate is 19-fold (1.27 log units) below it; measured number outside the range, above it.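

Carrying this change to the second core does not repeat the earlier result: in this assay it brings an 11-fold higher number from compound 2 to compound 4 (1.05 log units; beyond the scatter), whereas on the first core it gave a 2.7-fold lower number from compound 1 to compound 3 (0.44 log units; beyond the scatter). The two steps point in opposite directions and their gap is real: the same change on two cores in this assay, a 2.7-fold lower number (0.44 log units; beyond the scatter) from compound 1 to compound 3 and an 11-fold higher number (1.05 log units; beyond the scatter) from compound 2 to compound 4, 30-fold (1.48 log units) apart, beyond the scatter of two such steps. The effect of this chain change therefore cannot be transferred from one core to the other in this series, although these two pairs alone do not show what in the cores causes the difference or what a third core would do.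

Still open, on these data alone, is how a longer chain would behave on each core. Also open, as far as these compounds go, is whether a carboxylic acid in place of the hydroxycarbamoyl at the chain end would follow the same split.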